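Aromatic Group onto the Amine Methyl of Compound 2

The compounds below may be only part of what the source reports. "The series", "measured", "known", "first", "only" and "open" are said of these compounds alone.

In an assay on isolated protein for activation of cGMP-dependent protein kinase 1 (Homo sapiens), read by ADP-Glo, with stated times of 120 min and 40 min (on this read-out higher numbers stand for an effect only at larger amounts of compound and lower numbers for an effect already at smaller amounts), compound 2 `CN1CCC[C@H](OCc2cc(Cl)cc(Cl)c2)[C@@H]1c1ccccc1` gives only a limit, > 200000 nM. Compound 1 `OC[C@@H](O[C@H]1CCCN(Cc2cccc3nonc23)[C@H]1c1ccccc1)c1cc(Cl)cc(Cl)c1` gives 8000 nM in this assay, and compound 3 `O=C(O)c1ccc(CN2CCC[C@H](O[C@H](CO)c3cc(Cl)cc(Cl)c3)[C@@H]2c2ccccc2)cc1` gives 11000 nM; each of these carries an aromatic group on the saturated chain carbon bound to the amine nitrogen in the ring, where compound 2 carries hydrogen. Compound 4 `COc1ccc(C(=O)O)cc1CN1CCC[C@H](OCc2cc(Cl)cc(Cl)c2)[C@@H]1c1ccccc1` differs from compound 2 by 5-carboxy-2-methoxyphenyl in place of hydrogen on a saturated chain carbon bound to an amine nitrogen in a ring. Going by the values given here, the only measured step, a 1.4-fold higher number from compound 1 to compound 3 (0.14 log units; within the scatter), exchanges one aromatic group for another at that carbon and so bears only indirectly on the present change; no measured step goes from hydrogen to an aromatic group there. Compound 2 sits at the limit of > 200000 nM in this assay, at which 1 of the 3 values shown sits. Given that, and given that compound 3, carrying a carboxy-bearing aromatic group there, gives 11000 nM, compound 4 is expected at 30000 nM, in the range 8000 nM to 150000 nM. That would be an expected step of an at least 6.6-fold lower number from compound 2 to compound 4 (0.82 log units; beyond the scatter).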

Compound 4, half-maximal effective concentration: 123000 nM
Beside the measured number, compound 4's estimate is 4.1-fold (0.61 log units) below it, within the range that was stated.
By their numbers in this assay, from the lowest: compounds 1 and 3 (each within the scatter of the next); then compound 4. At a limit, above all of these: compound 2.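

In this assay, replacing hydrogen with an aromatic group on a saturated chain carbon bound to an amine nitrogen in a ring can now be read directly: an at least 1.6-fold lower number from compound 2 to compound 4 (0.21 log units; that floor lies within the scatter). This step therefore gives only a floor and does not establish that 5-carboxy-2-methoxyphenyl lowers the number. Compound 2 gives only a limit, so the full size of the step cannot be read: the limit of > 200000 nM in this assay, at which 1 of the 4 values shown sits.

From the compounds shown here alone, the effect of an amine in place of the carboxy group on this aromatic ring remains open. So does the effect of a plain phenyl at this carbon.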